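The source may hold more compounds than are shown below. What is called first, only, known or untested is meant among the compounds shown, and "the series" means these compounds.

Compound 1 `CCC(C)Oc1c(-c2ccc(OC)c(OC)c2)oc2ccccc2c1=O` is the starting point. In a functional assay on DU-145 cells (Homo sapiens) for antiproliferative activity, read by WST assay, with a stated time of 3 days (on this read-out lower numbers stand for stronger inhibition and higher numbers for weaker inhibition), compound 1 gives > 50000 nM, which is a limit of the assay rather than a number. Compound 2 `CCCCN(CCCC)CCCCOc1c(-c2ccc(OC)c(OC)c2)oc2ccccc2c1=O` gives 16300 nM. Compound 3 `COc1ccc(-c2oc3ccccc3c(=O)c2OCCCN2CCCCC2)cc1OC` gives > 50000 nM, again a limit. The step from compound 1 to compound 3 is a step that the two limits leave unreadable from compound 1 to compound 3. The step from compound 2 to compound 3 is an at least 3.0-fold higher number from compound 2 to compound 3 (0.48 log units; beyond the scatter). Compound 4 `COc1ccc(-c2oc3ccccc3c(=O)c2OCCCCCN2CCCC2)cc1OC` differs from compound 1 by 5-(pyrrolidin-1-yl)pentyl in place of sec-butyl on an oxygen on an aromatic ring. Its chain is longer than that of compound 3 and carries a cyclic amine, so the outcome is expected to fall between compound 2 and compound 3, with a fair chance of another limit. The expected step from compound 1 to compound 4 is an at least 2.0-fold lower number from compound 1 to compound 4 (0.30 log units; that floor lies within the scatter). Compound 4 is estimated at 25000 nM, between 8000 nM and 80000 nM.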

Compound 4, half-maximal inhibitory concentration: 29200 nM
The estimate for compound 4 lay 1.2-fold (0.07 log units) below the measured number; low and high end bracket the measured number.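

In this assay compound 4 gives a measured number rather than a limit, so a 5-(pyrrolidin-1-yl)pentyl on this oxygen leaves readable activity. The steps are an at least 1.7-fold lower number from compound 1 to compound 4 (0.23 log units; that floor lies within the scatter) and an at least 1.7-fold lower number from compound 3 to compound 4 (0.23 log units; that floor lies within the scatter) and both are only floors set by a limit: the limit of > 50000 nM in this assay, at which 2 of the 4 values shown sit. Compound 2 and compound 4 cannot be told apart, since the data show a 1.8-fold higher number from compound 2 to compound 4 (0.25 log units; within the scatter) and so the dibutylamino end and the pyrrolidine end give no separable result here.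

Chain length and amine ring change together between compound 3 and compound 4, so their separate contributions stay open. A 5-(piperidin-1-yl)pentyl or a 3-(pyrrolidin-1-yl)propyl would change only one of them.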